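A few compounds are considered here, and "the series" means these few. Any claim that something is new, unique, unknown or untested is made for them only; others in the source may bear on it.

In a functional assay on SiHa cells (Homo sapiens) for inhibition, read by sulforhodamine B assay (a lower number here means a stronger inhibitor of growth, a higher number a weaker inhibitor of growth), three compounds built on a shared core have been measured. Compound 1 `Cc1ccc2[nH]c(-c3ccc(-c4ccc(-c5cccc(Cl)c5)cc4)cc3)nc2c1` gives 3600 nM and compound 2 `COc1cc(-c2ccc(-c3ccc(-c4nc5cc(C)ccc5[nH]4)cc3)cc2)cc(OC)c1OC` gives 170 nM in this test, while compound 3 `FC(F)(F)c1ccc(-c2ccc(-c3ccc(-c4nc5ccccc5[nH]4)cc3)cc2)cc1` stands at 100000 nM as the highest of the three numbers. It is therefore the weakest inhibitor of growth in the set, and its gaps to both other compounds lie beyond the scatter.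

Compound 4 `CN(C)c1ccc(-c2ccc(-c3ccc(-c4nc5ccccc5[nH]4)cc3)cc2)cc1` departs from compound 3 in one place, with dimethylamino in place of trifluoromethyl on an aromatic carbon, para to a large group dimethylamino in place of trifluoromethyl on an aromatic carbon as the counted difference. Among the measured compounds shown here, no pair of measured compounds differs in one place only, so the effect of this change has not been seen directly. The expectation rests on the two other measured values, compound 1 (3600 nM) and compound 2 (170 nM), both far lower than the value of compound 3 (100000 nM) although each differs from it in more than one place. A fall in the number is therefore expected, with the estimated step of a 50-fold lower number from compound 3 to compound 4 (1.70 log units; beyond the scatter) lying beyond the scatter. For compound 4 the estimated value is 2000 nM with an expected range from 150 nM to 30000 nM in this test.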

Compound 4, concentration for 50% growth inhibition: 100000 nM
Compound 4: middle estimate off by 50-fold (1.70 log units), on the low side; the measured number lies above the stated range.
By their numbers in this assay, from the lowest: compound 2; then compound 1; then compounds 3 and 4 (each within the scatter of the next).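

In this assay, among the compounds shown here, putting dimethylamino in place of trifluoromethyl on an aromatic carbon, para to a large group, gives no change at the digits printed from compound 3 to compound 4 (within the scatter), which is the first direct reading of a single change in this set. At this position, on the core shared by compound 3 and compound 4, the exchange of a group with no hydrogen-bond acceptor for one with a hydrogen-bond acceptor therefore leaves the growth-inhibition number unmoved, so this change alone does not bring the pair toward the lower values seen elsewhere in the series. No measurement at hand accounts for this absence of change.

The steps from this pair to compound 1 and compound 2 cannot be read, as those compounds differ from it in more than one place, so the roles of the methyl on the core and of the chloro and trimethoxy patterns on the far ring stay unresolved. On these data alone, it also stays open whether a primary amine, a carboxylic acid or a longer chain at this position would shift the number, or whether dimethylamino would behave the same way with the methyl present on the core.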